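From oxan-4-yl to 4-methoxycyclohexyl on the amide nitrogen

The source may report more compounds than this note shows. Statements on the series, on what has been measured and on what is new or still open speak of the compounds shown alone.

Compound 3 `CCN(CC)S(=O)(=O)c1ccc(S(=O)(=O)N2CCC[C@@H](C(=O)NC3CCOCC3)C2)cc1` gives > 10000 nM in a functional assay on MIA PaCa-2 cells (Homo sapiens) for inhibition, read by MTT assay, with a stated time of 3 days (a higher number here means a weaker inhibitor, a lower number a stronger inhibitor), which is a limit and not a number. Compound 1 `CCN(CC)S(=O)(=O)c1ccc(S(=O)(=O)N2CCC[C@@H](C(=O)N3CCC(O)CC3)C2)cc1` gives > 10000 nM in this assay, also a limit. Compound 2 `O=C([C@@H]1CCCN(S(=O)(=O)c2ccc(S(=O)(=O)C3CCC3)cc2)C1)N1CCC(F)(F)CC1` gives > 3000 nM in this assay, again a limit. Going by the values given here, no compound in the set therefore has a numerical reading.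

Compound 4 `CCN(CC)S(=O)(=O)c1ccc(S(=O)(=O)N2CCC[C@@H](C(=O)N[C@H]3CC[C@@H](OC)CC3)C2)cc1` carries 4-methoxycyclohexyl in place of oxan-4-yl on an amide-type nitrogen. Among the compounds with values here, the only measured step at this part of the molecule is a step that the two limits leave unreadable from compound 1 to compound 3, so it offers no size to carry over. The starting point for compound 4 is compound 3 at > 10000 nM, a limit, and the expectation in this assay is correspondingly loose: little change, with at most a modest strengthening. The expected change is an at least 1.2-fold lower number from compound 3 to compound 4 (0.09 log units; that floor lies within the scatter). For compound 4 the estimated value is 8000 nM, with an expected range from 500 nM to 20000 nM.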

Compound 4, half-maximal inhibitory concentration: > 10000 nM
Compound 4 was reported as a limit; the forecaster's own chance of this, stated with the estimate: 55%; at least 1.2-fold (0.09 log units) between middle value and limit.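

The steps to compound 4 from compound 3 and from compound 1 cannot be read, because all three compounds stand at the same limit: the limit of > 10000 nM in this assay, at which 3 of the 4 values shown sit.

The compounds shown leave open whether these amide groups change inhibition in this assay at all, and by how much.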